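Notes on the step from compound 3 to compound 4

The compounds below may be only part of what the source reports. "The series", "measured", "known", "first", "only" and "open" are said of these compounds alone.

Compound 1 (`COc1ccc(/C=C/C(=O)c2ccc(OC)c3c2OC(C)(C)C=C3)cn1`), compound 2 (`COc1ccc(C(=O)/C=C/c2ccco2)c2c1C=CC(C)(C)O2`) and compound 3 (`COc1ccc(C(=O)/C=C/c2cccc(Cl)c2)c2c1C=CC(C)(C)O2`) share one core. In a functional assay on SK-OV-3 cells (Homo sapiens) for antiproliferative activity, read by MTT assay, with a stated time of 24 h (a higher number here means a weaker inhibitor, a lower number a stronger inhibitor), compound 1 gives > 10000 nM as a limit and not a number. Compound 2 gives > 10000 nM as a limit too. Compound 3 likewise gives > 10000 nM as a limit. Compound 3 therefore stands with the other two at the limit of > 10000 nM in this assay, at which 3 of the 3 values shown sit, and offers no number to start from.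

Compound 4 (`COc1ccc(C(=O)/C=C/c2ccc(O)c(Br)c2)c2c1C=CC(C)(C)O2`) has 3-bromo-4-hydroxyphenyl in place of 3-chlorophenyl on a double-bonded chain carbon bound to a double-bonded chain carbon.

Three measured steps change the group at that same place: a step that the two limits leave unreadable from compound 1 to compound 2 and a step that the two limits leave unreadable from compound 1 to compound 3 and also a step that the two limits leave unreadable from compound 2 to compound 3 all lack a readable size. They give no direction, so the expectation in this assay stays close to compound 3 at > 10000 nM as a limit. The expected step is a step that the limit leaves unreadable from compound 3 to compound 4 and it is held small. The estimate for compound 4 is 12000 nM (expected range 5000 nM to 30000 nM).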

Compound 4, half-maximal inhibitory concentration: > 10000 nM
Compound 4 was reported as a limit (the forecaster's own chance of this, stated with the estimate: 70%); the middle value lies beyond the limit too.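

For the compounds shown here, compound 1, compound 2, compound 3 and compound 4 all give only limits in this assay, so no step among them can be read: the limit of > 10000 nM in this assay, at which 4 of the 4 values shown sit.

The compounds shown leave open which group at this place, if any, would give a measurable value in this assay.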